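Sulfonyl aryl change on the fluoro-bearing series

This account rests on a few compounds, and the source may have more. Where it says the series, first, only, none or still open, it means among the compounds named here.

Measured so far in an assay on isolated protein for displacement of a labelled ligand from metabotropic glutamate receptor 5 (Homo sapiens), with a stated time of 60 min, tested at 1 uM; a lower number here means less inhibition, a higher number more inhibition at the concentration tested (going by the name of the read-out):
compound 1 `CC1CCN(c2c(S(=O)(=O)c3ccccc3)cnc3ccccc23)CC1`: 89.2%
compound 2 `CC1CCN(c2c(S(=O)(=O)c3ccccc3)cnc3c(F)cccc23)CC1`: 13%

Among the measured compounds shown here, compound 2 stands lowest of the two measured numbers; its nearest neighbour is compound 1, and the only measured step, a number 76.2 percentage points lower from compound 1 to compound 2 (beyond the scatter), is fluoro in place of hydrogen on an aromatic carbon. Compound 3 `CC1CCN(c2c(S(=O)(=O)c3ccc(Cl)c(Cl)c3)cnc3c(F)cccc23)CC1` keeps that fluoro and differs from compound 2 by 3,4-dichlorophenyl in place of phenyl on a sulfonyl sulfur.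

For the measured compounds named here, no measured step touches the group on the sulfonyl sulfur, so nothing measured bears directly on this change. Going by the values given here, the one step that is known shows only that a single small change can move the read-out far, so the expectation for compound 3 is wide rather than confident. Starting from the low number of compound 2, compound 3 is estimated at 25%, within 5% to 60%. The step expected from this change is a number 12 percentage points higher from compound 2 to compound 3 (beyond the scatter).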

Compound 3, a percentage reported as inhibition, at one concentration (the size of the read-out at that concentration, not a potency): 95%
The estimate for compound 3 lay 70 percentage points below the measured number; the whole stated range lies below it.
By their numbers in this assay, from the lowest: compound 2; then compounds 1 and 3 (each within the scatter of the next).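

In this assay, the group on the sulfonyl sulfur emerges as a second place in this series where one change moves the read-out far: 3,4-dichlorophenyl in place of phenyl gives a number 82 percentage points higher from compound 2 to compound 3 (beyond the scatter), with the fluoro kept. The low number of compound 2 is therefore not set by the fluoro alone, since that fluoro is also present in compound 3, which gives 95% in the same test. Nothing at hand accounts for the size of this step.

Still open, going by these compounds, is whether one chlorine alone on the phenyl would carry the step, and whether the same exchange would act alike on the core of compound 1. Also open, on these data alone, is how a pyridine ring or a methoxy-bearing phenyl on the sulfonyl sulfur would read in this assay at this concentration.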